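From 4-chlorophenyl to 2-fluorophenyl on the ethenyl chain

The source may hold more compounds than are shown below. What is called first, only, known or untested is meant among the compounds shown, and "the series" means these compounds.

In a functional assay on Caco-2 cells (Homo sapiens) for inhibition, read by MTT assay, with a stated time of 48 h, tested at 10 uM (a lower number here means less inhibition of growth, a higher number more inhibition of growth at the concentration tested), compound 1 (`Cc1oc2c([C@H]3CCN(C)C[C@H]3O)c(O)cc(O)c2c(=O)c1C(O)c1ccc([N+](=O)[O-])cc1`) gives 5% and compound 2 (`Cc1oc2c([C@H]3CCN(C)C[C@H]3O)c(O)cc(O)c2c(=O)c1C(O)c1ccc(F)c(Br)c1`) gives 6%. Compound 3 (`CN1CC[C@H](c2c(O)cc(O)c3c(=O)cc(/C=C/c4ccc(Cl)cc4)oc23)[C@H](O)C1`) stands highest of the three at 70%. Compound 4 (`CN1CC[C@H](c2c(O)cc(O)c3c(=O)cc(/C=C/c4ccccc4F)oc23)[C@H](O)C1`) departs from compound 3 in one place: 2-fluorophenyl in place of 4-chlorophenyl on a double-bonded chain carbon bound to a double-bonded chain carbon. It carries 2-fluorophenyl in place of 4-chlorophenyl on a double-bonded chain carbon bound to a double-bonded chain carbon.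

Within the data shown here, only one measured step offers any guide, and it is indirect. That step, a number 1 percentage points higher from compound 1 to compound 2 (within the scatter), exchanges one substituted phenyl for another, but on a saturated chain carbon rather than on the double-bonded chain. The data hold no measured change of the phenyl group on the chain of compound 3, so the direction remains uncertain. A moderate loss from the high value of compound 3 is expected, though no change beyond the scatter remains possible. The estimate amounts to a number 12 percentage points lower from compound 3 to compound 4 (beyond the scatter). Compound 4 is expected to reach 58%, within an estimated range of 30% to 80%.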

Compound 4, percent growth inhibition at one concentration: 68%
For compound 4 the middle estimate is 10 percentage points below the measured one; low and high end bracket the measured number.
By their numbers in this assay, from the lowest: compounds 1 and 2 (each within the scatter of the next); then compounds 4 and 3 (each within the scatter of the next).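

In this assay, 2-fluorophenyl in place of 4-chlorophenyl on the ethenyl chain gives a number 2 percentage points lower from compound 3 to compound 4 (within the scatter). Among these compounds, this is the first measured exchange at this place, a double-bonded chain carbon bound to a double-bonded chain carbon, and it shows that the high reading of compound 3 does not depend on the 4-chlorophenyl group alone, since compound 4 with 2-fluorophenyl reads the same within the scatter. No measurement at hand accounts for this outcome.

Both the halogen and its place on the phenyl differ in this single step, so the two changes cannot be told apart from these compounds. On these data alone, whether an unsubstituted phenyl, a methoxyphenyl or a pyridine ring on the ethenyl chain would give a similar number remains open.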